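The source may report more compounds than this note shows. Statements on the series, on what has been measured and on what is new or still open speak of the compounds shown alone.

Compound 1, `CCOC(=O)c1cnc(-c2csc(C)n2)nc1NN1C(=O)C=C(C)C1=O`, is the weakest of the three measured compounds in a functional assay on Jurkat cells for inhibition of nuclear factor NF-kappa-B complex (Homo sapiens) (a higher number here means a weaker inhibitor, a lower number a stronger inhibitor), where compound 1 gives 8000 nM. Compound 2, `CCOC(=O)c1cnc(-c2ccc(C(F)(F)F)cc2)nc1NN1C(=O)C=C(C)C1=O`, gives 400 nM in this assay, and compound 3, `CCOC(=O)c1cnc(-c2cccc(Br)c2)nc1NN1C(=O)C=C(C)C1=O`, gives 700 nM. The two steps away from compound 1 are both large: a 20-fold lower number from compound 1 to compound 2 (1.30 log units; beyond the scatter), and an 11-fold lower number from compound 1 to compound 3 (1.06 log units; beyond the scatter). Between the two stronger compounds the gap is small, a 1.8-fold higher number from compound 2 to compound 3 (0.24 log units; within the scatter).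

Compound 4, `CCOC(=O)c1cnc(C(=O)c2ccco2)nc1NN1C(=O)C=C(C)C1=O`, has not yet been measured. It differs from compound 1 in one place: (furan-2-yl)carbonyl in place of 2-methyl-1,3-thiazol-4-yl on an aromatic carbon. The measured steps that bear on this change are the two that also remove the 2-methyl-1,3-thiazol-4-yl group from compound 1, namely the steps to compound 2 and to compound 3, both of which gave much lower numbers. Going by these compounds, the group entering in compound 4, (furan-2-yl)carbonyl, is not the same kind of group as 4-(trifluoromethyl)phenyl or 3-bromophenyl, so how far those steps carry over is unknown. Compound 4 is therefore expected to give a lower number than compound 1 in this assay, with a step estimated as a 2.3-fold lower number from compound 1 to compound 4 (0.36 log units; beyond the scatter), smaller than the two measured ones. The estimate for compound 4 in this assay is 3500 nM, in a range from 900 nM to 14000 nM.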

Compound 4, half-maximal inhibitory concentration: 700 nM
The estimate for compound 4 lay 5.0-fold (0.70 log units) above the measured number, outside the stated range (below it).
By their numbers in this assay, from the lowest: compounds 2, 3 and 4 (each within the scatter of the next); then compound 1.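

In this assay, the step of an 11-fold lower number from compound 1 to compound 4 (1.06 log units; beyond the scatter) shows that the large change at this position, on the aromatic carbon between two ring nitrogen atoms, does not depend on a phenyl ring, since a (furan-2-yl)carbonyl group gives it as well. The new group also cannot be told apart from either phenyl group, with no change at the digits printed from compound 3 to compound 4 (within the scatter) and a 1.8-fold higher number from compound 2 to compound 4 (0.24 log units; within the scatter) as the readings, so three rather different groups fall together here and only the 2-methyl-1,3-thiazol-4-yl group of compound 1 stands apart. Having a five-membered aromatic ring at this position does not by itself set compound 1 apart, as compound 4 carries one too.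

No measurement offered here accounts for any of these steps. Going by these compounds, it remains open whether the furan ring or the carbonyl matters more in compound 4, which a directly attached furan-2-yl group or a benzoyl group would help to separate, and how an amine or a longer alkyl chain at this position would read in this assay.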